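The source may hold more compounds than are shown below. What is called first, only, known or untested is meant among the compounds shown, and "the series" means these compounds.

Measured so far in an ADME assay on BJ cells (Homo sapiens) for cytotoxicity, with a stated time of 72 h; a lower number here means that less compound is needed, a higher number that more compound is needed for the effect:
- compound 1 `CSc1ccc(NC(=O)Nc2cc(C)nc3ccccc23)cc1`: > 25000 nM (a limit)
- compound 2 `CC(=O)c1ccc(NC(=O)Nc2cc(C)nc3ccccc23)cc1`: 22000 nM
- compound 3 `Cc1cc(NC(=O)Nc2ccc(F)cc2)c2ccccc2n1`: > 25000 nM (a limit)

Not yet measured: compound 4 `COC(=O)c1ccc(NC(=O)Nc2cc(C)nc3ccccc23)cc1`.

Compound 3 stands at > 25000 nM, which is a limit of the assay and not a number. It shares this position with one other compound: the limit of > 25000 nM in this assay, at which 2 of the 3 values shown sit.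

The next step puts methoxycarbonyl in place of fluoro on an aromatic carbon, para to a large group: methoxycarbonyl in place of fluoro on an aromatic carbon.

The nearest measured change is fluoro in place of acetyl, an at least 1.1-fold higher number from compound 2 to compound 3 (0.05 log units; that floor lies within the scatter). The change of acetyl in place of methylsulfanyl gives an at least 1.1-fold lower number from compound 1 to compound 2 (0.05 log units; that floor lies within the scatter). Fluoro in place of methylsulfanyl gives a step that the two limits leave unreadable from compound 1 to compound 3. None of these shows a step beyond the scatter, so none is expected here in this assay, in either direction. Among the compounds with values here, the one true number is from compound 2, at 22000 nM, and it anchors the expectation.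

The expected step is an at least 1.0-fold lower number from compound 3 to compound 4 (0.03 log units; that floor lies within the scatter). For compound 4 the estimated value is 23000 nM, with an expected range of 12000 nM to 40000 nM.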

Compound 4, half-maximal effective concentration: 21000 nM
For compound 4 the middle estimate is 1.1-fold (0.04 log units) above the measured one; the range from low to high includes it.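

In this assay, within the data shown here, methoxycarbonyl on this aromatic carbon, para to a large group, gives the series a second true number, where the earlier compounds offered only one. Methoxy in place of methyl on a carbonyl carbon is thus the first step with a true number at both ends, and it stays within the scatter: a 1.0-fold lower number from compound 2 to compound 4 (0.02 log units; within the scatter). The other two steps, an at least 1.1-fold lower number from compound 3 to compound 4 (0.07 log units; that floor lies within the scatter) and an at least 1.1-fold lower number from compound 1 to compound 4 (0.07 log units; that floor lies within the scatter), give only floors within the scatter, because compound 1 and compound 3 rest on a limit of the assay: the limit of > 25000 nM in this assay, at which 2 of the 4 values shown sit.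

The compounds shown leave open whether any group at this place gives a step beyond the scatter. Also open, from the compounds shown here alone, is what a carboxylic acid or an amine on this aromatic carbon would give.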